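Trifluoromethoxy addition on the anilino-pyrimidine scaffold

The compounds below may be only part of what the source reports. "The series", "measured", "known", "first", "only" and "open" are said of these compounds alone.

Measured compounds:
compound 1 `FC(F)(F)Oc1cccc(NCc2cnc3ccccc3c2)c1` — 5.2 uM
compound 2 `c1ccc(NCc2cncnc2)cc1` — 9.6 uM

In a functional assay with metabotropic glutamate receptor 2 (Homo sapiens) as the target, read by GTPgammaS binding, in the presence of a further agent that is not named here (on this read-out lower numbers stand for an effect already at smaller amounts and higher numbers for an effect only at larger amounts of compound), compound 1 gives 5.2 uM and compound 2 gives 9.6 uM. For the measured compounds named here, compound 2 holds the highest of the two numbers measured so far; its nearest neighbour is compound 1, and the gap between the two lies within the usual scatter, so no order between them can be claimed. Going by the values given here, the two compounds differ in more than one place, so no single step between them is defined.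

Compound 3 `FC(F)(F)Oc1cccc(NCc2cncnc2)c1` is not yet measured. It differs from compound 2 in one place: trifluoromethoxy in place of hydrogen on an aromatic carbon. The same trifluoromethoxy group is present in compound 1, but compound 1 also carries a different core, so the contribution of the group alone cannot be read from the two measured numbers.

Among the compounds with values here, with no isolated step available, the expectation for compound 3 rests on the closeness of compound 1 at 5.2 uM and compound 2 at 9.6 uM: a step toward a lower number is expected, but small, and possibly not beyond the scatter. The expected step is a 2.1-fold lower number from compound 2 to compound 3 (0.33 log units; beyond the scatter). Compound 3 is thus estimated at 4.5 uM, within a range from 1.5 uM to 13 uM.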

Compound 3, concentration for half-maximal effect: 19 uM
Compound 3: the middle estimate sits 4.2-fold (0.63 log units) below what was measured, outside the stated range (above it).
By their numbers in this assay, from the lowest: compounds 1, 2 and 3 (each within the scatter of the next, the first and the last beyond it).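

In this assay, trifluoromethoxy in place of hydrogen on an aromatic carbon, on a six-membered aromatic ring of carbon only and meta to a group of 8 heavy atoms, gives a 2.0-fold higher number from compound 2 to compound 3 (0.30 log units; within the scatter), so this single change cannot be told apart from repeat scatter. For the compounds shown here, this is the first isolated reading of the group, which the comparison of the two earlier compounds could not give: on the core shared by compound 2 and compound 3, the five added heavy atoms are accommodated at this place, with no clear shift in either direction on this read-out. No accompanying measurement bears on the reason for this result.

Open, from the compounds shown here alone, is whether a different group at this same place, such as an amine, a carboxylic acid or a longer alkyl chain, would give a step beyond the scatter, or whether this place responds little to substitution in general. Also open is whether trifluoromethoxy behaves the same way on the core of compound 1, since no one-place pair on that core is shown here.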